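The source may hold more compounds than are shown below. What is called first, only, known or untested is meant among the compounds shown, and "the series" means these compounds.

Among the compounds with values here, in a functional assay on K562 cells (Homo sapiens) for cytotoxicity, read by MTT assay, with a stated time of 72 h (a lower number here means a stronger inhibitor, a higher number a weaker inhibitor), compound 1 `CCCCOCNc1n[n+]([O-])c2ccccc2[n+]1[O-]` gives 17600 nM, the highest of the two numbers measured so far. Compound 2 `COc1ccc2c(c1)[n+]([O-])nc(NCOC(C)c1ccccc1)[n+]2[O-]` gives 6690 nM in this assay, a lower number that lies beyond the scatter. Compound 3 `CC(C)CCOCNc1n[n+]([O-])c2ccccc2[n+]1[O-]` has not yet been measured. It differs from compound 1 by methyl in place of hydrogen on a saturated chain carbon bound to two saturated chain carbons. Nothing measured here shows what such a change does to the number, so only a shift within the scatter is expected, a 1.3-fold lower number from compound 1 to compound 3 (0.10 log units; within the scatter), with no clear direction. Compound 3 is therefore expected to give about 14000 nM, somewhere between 7000 nM and 30000 nM.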

Compound 3, half-maximal inhibitory concentration: 13100 nM
Beside the measured number, compound 3's estimate is 1.1-fold (0.03 log units) above it; low and high end bracket the measured number.
By their numbers in this assay, from the lowest: compounds 2, 3 and 1 (each within the scatter of the next, the first and the last beyond it).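

Methyl in place of hydrogen on a saturated chain carbon bound to two saturated chain carbons turns butyl into isopentyl, and in this assay this gives a 1.3-fold lower number from compound 1 to compound 3 (0.13 log units; within the scatter) as its step. This position therefore takes the added methyl without a shift that can be told apart from repeat measurements. Nothing available here gives a measured reason for this result. Going by these compounds, whether a longer chain, an amine or a carboxylic acid at this place would move the number beyond the scatter stays open.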